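Ethynyl to chloro at the limit of the assay

The compounds below may be only part of what the source reports. "The series", "measured", "known", "first", "only" and "open" are said of these compounds alone.

In a functional assay on MCF7 cells (Homo sapiens) for cytotoxicity, read by MTT assay, with a stated time of 72 h (on this read-out higher numbers stand for weaker inhibition and lower numbers for stronger inhibition), compound 1 (`C#Cc1cccc(Nc2ncnc3oc(C)c(C(=O)OCC)c23)c1`) gives only a limit (> 1000000 nM). Compound 2 (`CCCNC(=O)c1c(C)oc2ncnc(Nc3cccc(C)c3)c12`) likewise gives only a limit (> 1000000 nM). Compound 3 (`Cc1oc2ncnc(Nc3ccccc3)c2c1C(=O)O`) gives a number (246000 nM). Compound 1 thus stands with compound 2 at the limit of > 1000000 nM in this assay, at which 2 of the 3 values shown sit, and has no exact value.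

Compound 4 (`CCOC(=O)c1c(C)oc2ncnc(Nc3cccc(Cl)c3)c12`) carries chloro in place of ethynyl on an aromatic carbon, meta to a large group (chloro in place of ethynyl on an aromatic carbon). Among the compounds with values here, no measured pair isolates this change, so no step beyond the scatter is expected in this assay, in either direction. The expected step runs a number no higher from compound 1 to compound 4 (the limit leaves the size open) and is estimated to be small. For compound 4 the estimate is 1000000 nM, with an expected range from 300000 nM to 3000000 nM and a good chance of another limit.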

Compound 4, half-maximal inhibitory concentration: > 1000000 nM
Compound 4 ended at the assay's limit; the forecaster's own chance of this, stated with the estimate: 70%; the middle value lies on the limit itself.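

Compound 1 and compound 4 both give only a limit, so no step can be read between them: the limit of > 1000000 nM in this assay, at which 3 of the 4 values shown sit.

The compounds shown leave open whether chloro in place of ethynyl on an aromatic carbon shifts the value in this assay at all.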